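Swapping 1H-imidazol-5-yl for ethyl on a carbonyl carbon

This account rests on a few compounds, and the source may have more. Where it says the series, first, only, none or still open, it means among the compounds named here.

Values in a toxicity assay on THP-1 cells (Homo sapiens) for inhibition; a higher number here means that more compound is tolerated, a lower number that less compound is tolerated:
Compound 1 `COc1ccc(-c2cnc(NC(=O)c3ccccc3O)n2C)cc1`: > 100000 nM
Compound 2 `COc1ccc(-c2cnc(NC(=O)c3cnc[nH]3)n2C)cc1`: > 100000 nM

Both entries are limits of the assay, not numbers. As far as these compounds go, compound 2 therefore stands at its limit of > 100000 nM in this assay, and its true value remains unknown.

Compound 3 `CCC(=O)Nc1ncc(-c2ccc(OC)cc2)n1C` carries ethyl in place of 1H-imidazol-5-yl on a carbonyl carbon. Among the compounds with values here, the only measured step bearing on this change, a step that the two limits leave unreadable from compound 1 to compound 2, also swaps the group on the carbonyl carbon. Its two compounds share a single limit: the limit of > 100000 nM in this assay, at which 2 of the 2 values shown sit. The data thus offer no step size to carry over, and no shift beyond the usual scatter is expected in this assay. The estimated a number no higher from compound 2 to compound 3 (the limit leaves the size open) reflects this. Compound 3 is expected at 100000 nM, with an estimated range from 40000 nM to 200000 nM, and may well be reported as a limit again.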

Compound 3, half-maximal cytotoxic concentration: > 100000 nM
Compound 3: only a limit was reported (the forecaster's own chance of this, stated with the estimate: 85%); the middle value sits exactly at the limit.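

Within the data shown here, compound 1, compound 2 and compound 3 all stop at one shared limit in this assay, so no step among them can be read: the limit of > 100000 nM in this assay, at which 3 of the 3 values shown sit. The compounds shown leave open how much of each the cells tolerate, and whether the group on the carbonyl carbon changes that at all.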